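The source may report more compounds than this note shows. Statements on the series, on what has been measured and on what is new or still open speak of the compounds shown alone.

Among the compounds with values here, in a functional assay on NCI-H1993 cells (Homo sapiens) for inhibition, read by CCK-8 assay, with a stated time of 72 h (a higher number here means a weaker inhibitor, a lower number a stronger inhibitor), only two compounds have been measured. Compound 1 `Oc1nc2ncc(-c3ccccc3)nc2n1Cc1ccc2ncccc2c1` reads > 10000 nM, which is a limit of the assay and not a number. Within the data shown here, compound 2 `OCCn1cc(-c2cnc3ncn(Cc4ccc5ncccc5c4)c3n2)cn1` gives 2330 nM, the only true number available, so it has no measured neighbour to be ranked against.

Compound 3 `c1ccc(-c2cnc3ncn(Cc4ccc5ncccc5c4)c3n2)cc1` departs from compound 2 in one place: phenyl in place of 1-(2-hydroxyethyl)-1H-pyrazol-4-yl on an aromatic carbon. It has phenyl in place of 1-(2-hydroxyethyl)-1H-pyrazol-4-yl, on an aromatic carbon of the six-membered aromatic ring with 2 nitrogen. Among the measured compounds shown here, no measured pair shows what such an exchange does, so the expectation is loose. With compound 2 at 2330 nM as the sole anchor, a small move towards a higher number is expected in this assay, hardly beyond the scatter. The estimated change is a 1.5-fold higher number from compound 2 to compound 3 (0.18 log units; within the scatter). The expected value for compound 3 is 3500 nM, within an estimated range of 1000 nM to 12000 nM.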

Compound 3, half-maximal inhibitory concentration: 7490 nM
Estimate against measurement, compound 3: 2.1-fold (0.33 log units) below; low and high end bracket the measured number.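

In this assay, the aromatic carbon carrying the 1-(2-hydroxyethyl)-1H-pyrazol-4-yl group now has its first readable exchange: phenyl in its place gives a 3.2-fold higher number from compound 2 to compound 3 (0.51 log units; beyond the scatter). Of these two groups, the 1-(2-hydroxyethyl)-1H-pyrazol-4-yl group therefore goes with the stronger inhibition at this position. At the second place of change, hydrogen in place of hydroxy on an aromatic carbon gives an at least 1.3-fold lower number from compound 1 to compound 3 (0.12 log units; that floor lies within the scatter), and this is only a floor, set by the value of compound 1, which is a limit and not a number: the limit of > 10000 nM in this assay, at which 1 of the 3 values shown sits.

The compounds shown leave open whether the difference at the first position lies with the pyrazole ring or with its hydroxyethyl chain. They also leave open what an unsubstituted pyrazole, or a longer chain ending in an amine or a carboxylic acid, would do on that carbon.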